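This account rests on a few compounds, and the source may have more. Where it says the series, first, only, none or still open, it means among the compounds named here.

In an ADME assay on microsomes from liver (Rattus norvegicus) for metabolic stability, read by LC-MS, using NADPH, with a stated time of 30 min, tested at 1 uM (a higher number here means that more of the compound is left, a lower number that less of the compound is left), the measured compounds read as follows.

compound 1 (`C=CC(=O)Nc1cc(Nc2ncc(Cl)c(Nc3ccccc3S(=O)(=O)C(C)C)n2)c(OC)cc1N(C)CCN(C)C`) gives 11%
compound 2 (`C=CC(=O)Nc1cc(Nc2ncc(F)c(Nc3ccccc3S(=O)(=O)C(C)C)n2)c(OC)cc1N(C)CCN(C)C`) gives 11%
compound 3 (`C=CC(=O)Nc1cc(Nc2nccc(Nc3ccccc3S(=O)(=O)C(C)C)n2)c(OC)cc1N(C)CCN(C)C`) gives 22%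

Compound 3 stands highest of the three. Compound 4 (`C=CC(=O)Nc1cc(Nc2ncc(I)c(Nc3ccccc3S(=O)(=O)C(C)C)n2)c(OC)cc1N(C)CCN(C)C`) differs from it by iodo in place of hydrogen on an aromatic carbon. Within the data shown here, three measured steps bear on this change. Hydrogen in place of chloro gave a modest step (a number 11 percentage points higher from compound 1 to compound 3 (beyond the scatter)), and hydrogen in place of fluoro gave one of the same size (a number 11 percentage points higher from compound 2 to compound 3 (beyond the scatter)). Fluoro in place of chloro gave none (no change at the digits printed from compound 1 to compound 2 (within the scatter)). Among the measured compounds shown here, no iodo compound has been measured, so the halogen steps are the only guide, and reversing them suggests a modest fall. The expected step is (a number 10 percentage points lower from compound 3 to compound 4 (within the scatter)) in this read-out. For compound 4 the estimated value is 12% (expected range 4% to 22%)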

Compound 4, percent of the compound remaining: 14%
Beside the measured number, compound 4's estimate is 2 percentage points below it; the range from low to high includes it.
By their numbers in this assay, from the lowest: compounds 1, 2, 4 and 3 (each within the scatter of the next, the first and the last beyond it).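

In this assay iodo at this position gives a number 8 percentage points lower from compound 3 to compound 4 (within the scatter) and so cannot be told apart from hydrogen, although chloro and fluoro can. Against fluoro it gives a number 3 percentage points higher from compound 2 to compound 4 (within the scatter) and against chloro a number 3 percentage points higher from compound 1 to compound 4 (within the scatter) and so cannot be told apart from them either. Iodo therefore bridges the two levels, and halogens as a set do not separate cleanly from hydrogen here. Nothing shown explains these numbers. From the compounds shown here alone, whether methyl, a nitrile or an amine at this position would leave more of the compound remaining stays open.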